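This account rests on a few compounds, and the source may have more. Where it says the series, first, only, none or still open, it means among the compounds named here.

Measured so far:
Compound 1 `Cc1cc(C)c(CN2CCc3c(Cl)cc(C(CO)c4ccon4)c(Cl)c3C2=O)c(=O)[nH]1`: 2490 nM; 122 nM (2 entries)
Compound 2 `Cc1cc(C)c(CN2CCc3c(Cl)cc([C@@H](CO)[C@@H]4CCCO4)c(Cl)c3C2=O)c(=O)[nH]1`: 1220 nM

Both compounds were tested in a functional assay on KARPAS-422 cells (Homo sapiens) for antiproliferative activity, read by resazurin assay, with a stated time of 72 h; a lower number here means a stronger inhibitor, a higher number a weaker inhibitor. Compound 2 gives 1220 nM, the only number shown for it, and one further entry for compound 2 carries no single number. Compound 1 gives widely separated results, (the several entries of compound 1 in this assay, 2490 nM; 122 nM (2 entries)), so a single reading in this assay is an uncertain anchor. Compound 3 `Cc1cc(C)c(CN2CCc3c(Cl)cc([C@@H](CO)[C@H]4CCCO4)c(Cl)c3C2=O)c(=O)[nH]1` has the same atoms and bonds as compound 2: the two compounds have the same atoms and bonds and differ only in configuration as drawn: 1 of 2 stereo elements differ; a stereocentre at a saturated ring carbon is drawn S in compound 2 and R in compound 3. Within the data shown here, no measured pair shows what such a change in configuration does. A moderate step toward stronger inhibition is expected, although a step in the opposite direction remains possible. The estimated step is a 2.0-fold lower number from compound 2 to compound 3 (0.31 log units; beyond the scatter). The estimated value for compound 3 is 600 nM, with an expected range of 70 nM to 3000 nM.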

Compound 3, half-maximal inhibitory concentration: 535 nM
For compound 3 the middle estimate is 1.1-fold (0.05 log units) above the measured one, within the range that was stated.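

In this assay, among these compounds, moving one stereocentre at a saturated ring carbon from S to R gives a 2.3-fold lower number from compound 2 to compound 3 (0.36 log units; beyond the scatter), which is the first measured sign that configuration at this carbon alone shifts the number. The step can be tied to that single change, because nothing else separates the two structures: the fact that compounds 2 and 3 differ only in the configuration as drawn. It remains a modest step in an assay where repeat readings can lie far apart, so one pair gives limited support: the several entries of compound 1 in this assay, 2490 nM; 122 nM (2 entries).

The compounds shown leave open how the second stereo element, drawn alike in compound 2 and compound 3, bears on the number. They also leave open whether an amine or a carboxylic acid in place of the saturated ring would keep the lower number of compound 3.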